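The compounds below may be only part of what the source reports. "The series", "measured", "known", "first", "only" and "open" are said of these compounds alone.

Series notes. Of the compounds shown here, three of a shared core have been measured: compound 1 `Nc1scc(CN2CCN(c3ccc(Cl)cc3Cl)CC2)c1C(=O)c1ccc(Cl)cc1`, compound 2 `Nc1scc(CN2CCN(C3CCCC3)CC2)c1C(=O)c1ccc(Cl)cc1` and compound 3 `Nc1scc(CN2CCN(c3ccc(F)cc3F)CC2)c1C(=O)c1ccc(Cl)cc1`. In an assay on CHO cells for displacement of a labelled ligand from adenosine receptor A3 (Homo sapiens), read by scintillation counting, with a stated time of 120 min, tested at 10 uM (a lower number here means less inhibition, a higher number more inhibition at the concentration tested (going by the name of the read-out)), compound 1 gives 0%, compound 2 gives 3% and compound 3 gives 0%. The single-point steps are all flat: a number 3 percentage points higher from compound 1 to compound 2 (within the scatter), no change at the digits printed from compound 1 to compound 3 (within the scatter) and a number 3 percentage points lower from compound 2 to compound 3 (within the scatter). Compound 3 thus stands level with compound 1 at the digits shown, the two together at the low end of the three numbers, with compound 2 nearest in structure among the aryl-bearing pair and compound 2 itself only a few points apart, all within the scatter. Within the data shown here, nothing so far has moved the read-out.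

The next compound is compound 4 `Nc1scc(CN2CCN(c3ccccc3Cl)CC2)c1C(=O)c1ccc(Cl)cc1`, which differs from compound 3 as follows: 2-chlorophenyl in place of 2,4-difluorophenyl on an amine nitrogen in a ring. Among the measured compounds shown here, the steps that bear on this are the swaps on the same ring nitrogen, which were flat from compound 1 to compound 3 and from compound 2 to compound 3; a halophenyl of either kind, or a cyclopentyl, gave the same near-zero inhibition. No step beyond the scatter is therefore expected in this assay, and the estimated step is a number 1 percentage points higher from compound 3 to compound 4 (within the scatter). Compound 4 is expected to give 1%, in the range 0% to 10%.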

Compound 4, a percentage reported as inhibition, at one concentration (the size of the read-out at that concentration, not a potency): 0%
The estimate for compound 4 lay 1 percentage points above the measured number, within the range that was stated.
By their numbers in this assay, from the lowest: compounds 1, 3, 4 and 2 (each within the scatter of the next).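

In this assay, 2-chlorophenyl in place of 2,4-difluorophenyl on the amine nitrogen in a ring gives no change at the digits printed from compound 3 to compound 4 (within the scatter) and 2-chlorophenyl in place of cyclopentyl gives a number 3 percentage points lower from compound 2 to compound 4 (within the scatter) so a phenyl carrying a single chloro and no fluorine joins the dichlorophenyl, difluorophenyl and cyclopentyl groups with no step beyond the scatter at this position. The earlier compounds shown here only exchanged whole groups, whereas hydrogen in place of chloro on an aromatic carbon is a change within the phenyl itself and gives no change at the digits printed from compound 1 to compound 4 (within the scatter) so taking away one chloro from the 2,4-dichlorophenyl group also leaves no readable step. No separate measurement is at hand that would account for these flat steps.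

Going by these compounds, with all four compounds close to zero inhibition, the read-out cannot separate the groups tested here, and any difference among them at a higher concentration stays unknown. On these data alone, it also remains open whether a benzyl, a pyridyl or an acetyl group on this ring nitrogen would give a number beyond the scatter.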